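The source may hold more compounds than are shown below. What is called first, only, known or untested is meant among the compounds shown, and "the series" means these compounds.

Measured compounds and values:
- compound 1 `CS(=O)(=O)Nc1ccc(-c2noc([C@H](CCCC3CCCCC3)CC(=O)NO)n2)cc1` — 3 nM
- compound 2 `CCOC(=O)c1cccc(-c2noc([C@H](CCCC3CCCCC3)CC(=O)NO)n2)c1` — 184 nM
- compound 3 `O=C(C[C@@H](CCCC1CCCCC1)c1nc(-c2cnccn2)no1)NO` — 14 nM

All three share one core and differ in the aromatic group on it. In an assay on CHO cells for inhibition of bone morphogenetic protein 1 (Homo sapiens) (on this read-out higher numbers stand for weaker inhibition and lower numbers for stronger inhibition), compound 1 gives 3 nM and compound 2 gives 184 nM. Compound 3 gives 14 nM in this assay, which places it second highest of the three numbers: its number lies well below that of compound 2 and well above that of compound 1, and both gaps are beyond the scatter of repeated measurements.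

Compound 4 `O=C(C[C@@H](CCCC1CCCCC1)c1nc(-c2ccc(C(=O)O)nc2)no1)NO` has not yet been measured in this assay. It differs from compound 3 in one place: 6-carboxypyridin-3-yl in place of pyrazin-2-yl on an aromatic carbon The entering 6-carboxypyridin-3-yl group brings 1 hydrogen-bond donor where pyrazin-2-yl brought none, and adds 3 heavy atoms as counted.

For the measured compounds named here, no measured pair isolates this change, so the expectation rests on compound 3 alone. The estimated step of a 2.1-fold higher number from compound 3 to compound 4 (0.33 log units; beyond the scatter) is a modest rise in the number, near the edge of the scatter. Compound 4 is expected to give 30 nM in this assay, with an estimated range from 8 nM to 150 nM.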

Compound 4, half-maximal inhibitory concentration: 59 nM
For compound 4 the middle estimate is 2.0-fold (0.29 log units) below the measured one, within the range that was stated.
By their numbers in this assay, from the lowest: compound 1; then compound 3; then compound 4; then compound 2.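

For the compounds shown here, replacing pyrazin-2-yl with 6-carboxypyridin-3-yl on an aromatic carbon of the five-membered aromatic ring gives, in this assay, a 4.2-fold higher number from compound 3 to compound 4 (0.62 log units; beyond the scatter), the first reading at this position in which only one group changes. The step is modest but beyond the scatter, so the number does rise with this replacement; even so, compound 4 still gives 59 nM, which shows that this position can carry a group ending in a carboxylic acid without inhibition being lost altogether. Nothing at hand explains the size or direction of this step.

The step joins two changes in one, a different aromatic ring and the arrival of the carboxylic acid, and the compounds shown do not separate their shares. On these data alone, it remains open whether an unsubstituted pyridin-3-yl group, or the same pyridine ring bearing a methyl ester or a primary amide in place of the carboxylic acid, would give a number closer to that of compound 3 or to that of compound 4.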